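The source may report more compounds than this note shows. Statements on the series, on what has been measured and on what is new or still open speak of the compounds shown alone.

Of the compounds shown here, three on the shared core have been measured in an assay on isolated protein (strain Sprague-Dawley) for inhibition of Amine oxidase [flavin-containing] A (Rattus norvegicus), read by spectrophotometry, with a stated time of 5 min, tested at 10 uM; a lower number here means less inhibition, a higher number more inhibition at the concentration tested (going by the name of the read-out). Compound 1 `CCNC(=O)Nc1cc(=O)oc2cc(OCc3cccc(Cl)c3)ccc12` gives 0%, compound 2 `O=c1cc(Nc2ccccc2)c2ccc(OCc3cccc(Cl)c3)cc2o1` gives 0%, and compound 3 `CCOC(=O)c1cc(=O)oc2cc(OCc3cccc(Cl)c3)ccc12` gives 4.4%. Compound 3 holds the highest of the three numbers, yet both steps onto it, a number 4.4 percentage points higher from compound 1 to compound 3 (within the scatter) and a number 4.4 percentage points higher from compound 2 to compound 3 (within the scatter), stay within the scatter, so the three compounds are not separated by this read-out. Compound 4 `O=C(O)c1cc(=O)oc2cc(OCc3cccc(Cl)c3)ccc12` differs from compound 3 by hydrogen in place of ethyl on an oxygen next to a carbonyl group. Among the compounds with values here, no measured step touches the oxygen next to the carbonyl group, and the steps that do exist on the core are all flat, so no step beyond the scatter is expected in this assay. For compound 4 the expected step is a number 1.4 percentage points lower from compound 3 to compound 4 (within the scatter). Compound 4 is therefore estimated at 3%, within 0% to 12%.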

Compound 4, a percentage reported as inhibition, at one concentration (the size of the read-out at that concentration, not a potency): 0%
Compound 4: the middle estimate sits 3 percentage points above what was measured, within the range that was stated.
By their numbers in this assay, from the lowest: compounds 1, 2, 4 and 3 (each within the scatter of the next).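

In this assay, the oxygen next to a carbonyl group now has a measured step of its own, a number 4.4 percentage points lower from compound 3 to compound 4 (within the scatter), so hydrogen in place of ethyl there does not separate the pair. Carboxy on the aromatic carbon is likewise not separated from the two nitrogen-linked groups: no change at the digits printed from compound 2 to compound 4 (within the scatter), and no change at the digits printed from compound 1 to compound 4 (within the scatter). No supporting measurement bears on this result.

Still open, from the compounds shown here alone, is whether any group on this aromatic carbon gives a number beyond the scatter, for instance a primary amine or a longer chain such as butoxycarbonyl.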